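The source may report more compounds than this note shows. Statements on the series, on what has been measured and on what is new or still open speak of the compounds shown alone.

In a functional assay on A549 cells (Homo sapiens) for cytotoxicity, read by MTT assay, with a stated time of 48 h (on this read-out higher numbers stand for weaker inhibition and lower numbers for stronger inhibition), compound 1 (`COc1ccc(-c2c(-c3cc(OC)c(OC)c(OC)c3)noc2N)cc1`) gives 4490 nM and compound 2 (`COc1cc(-c2noc(NC(C)=O)c2-c2ccc(Cl)cc2)cc(OC)c1OC`) gives 25000 nM while compound 3 (`COc1ccc(-c2c(-c3cc(OC)c(OC)c(OC)c3)noc2N(C(C)=O)C(C)=O)cc1`) gives the lowest of the three numbers (430 nM). Compound 4 (`COc1cc(-c2noc(N(C(C)=O)C(C)=O)c2-c2ccc(Cl)cc2)cc(OC)c1OC`) is unmeasured and differs from compound 3 by chloro in place of methoxy on an aromatic carbon. Among the compounds with values here, the one measured step (a 10-fold lower number from compound 1 to compound 3 (1.02 log units; beyond the scatter)) is diacetylamino in place of amino, a large change that leaves the swap of 4-methoxyphenyl to 4-chlorophenyl untested. Within the data shown here, compound 2 is the only measured compound with the 4-chlorophenyl group, and it lacks the diacetylamino group. Carrying a gain of the size of that one step (a 10-fold lower number from compound 1 to compound 3 (1.02 log units; beyond the scatter)) over to compound 2 (25000 nM) suggests a higher number for compound 4 than for compound 3, so in this assay a moderate rise is expected. The expected change is modest but beyond the scatter (a 4.7-fold higher number from compound 3 to compound 4 (0.67 log units; beyond the scatter)). For compound 4 the estimated value is 2000 nM and the expected range runs from 500 nM to 9000 nM as a working window.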

Compound 4, half-maximal inhibitory concentration: > 50000 nM
Compound 4: only a limit was reported (the forecaster's own chance of this, stated with the estimate: 5%); middle value at least 25-fold (1.39 log units) from the limit.
By their numbers in this assay, from the lowest: compound 3; then compound 1; then compound 2. At a limit, above all of these: compound 4.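

In this assay, within the data shown here, compound 4 gives only a limit, and the methoxy of the 4-methoxyphenyl group proves decisive on the diacetylamino series: an at least 110-fold higher number from compound 3 to compound 4 (2.06 log units; beyond the scatter), a change the earlier compounds never tested with the diacetylamino group held constant. Compound 4 stands at that limit: the limit of > 50000 nM in this assay, at which 1 of the 4 values shown sits. The added acetyl on the amide-type nitrogen of the 4-chlorophenyl pair shows no demonstrated gain, with an at least 2.0-fold higher number from compound 2 to compound 4 (0.30 log units; that floor lies within the scatter), so the drop in number of a 10-fold lower number from compound 1 to compound 3 (1.02 log units; beyond the scatter) holds only for the 4-methoxyphenyl pair, which also starts from a different nitrogen group.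

As far as these compounds go, whether fluoro, methyl or ethoxy in place of methoxy on this aromatic carbon keeps a number near that of compound 3 remains open. Also open, from the compounds shown here alone, is how far past its limit compound 4 lies, so the true size of both new steps cannot be fixed.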